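An Ether Ring Moved One Position Along the Carbonyl

The source may report more compounds than this note shows. Statements on the series, on what has been measured and on what is new or still open speak of the compounds shown alone.

Three measured compounds share one core. Compound 1 `O=C(Nc1ccc(C(F)(F)F)c(F)c1)NC1CCN(C(=O)C2(C(F)(F)F)CC2)CC1` gives 5.52 in a physicochemical assay for lipophilicity, read by HPLC, with a stated time of 90 min, tested at 100 uM (a higher number here means a more lipophilic compound, a lower number a more polar compound), and compound 2 `CC[C@H](C)C(=O)N1CCC(NC(=O)Nc2ccc(C(F)(F)F)c(F)c2)CC1` gives 5.48; the two lie within the scatter, a number 0.04 log units lower from compound 1 to compound 2 (within the scatter). Compound 3 `O=C(Nc1ccc(C(F)(F)F)c(F)c1)NC1CCN(C(=O)C2CCCOC2)CC1` gives 3.84 and stands lowest of the three, with compound 2 nearest and compound 1 furthest, both beyond the scatter.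

The step now followed goes from compound 3 to compound 4 `O=C(Nc1ccc(C(F)(F)F)c(F)c1)NC1CCN(C(=O)C2CCOCC2)CC1`: oxan-4-yl in place of oxan-3-yl on a carbonyl carbon. The two have the same atoms, joined differently.

The measured steps bearing on this are a number 1.68 log units lower from compound 1 to compound 3 (beyond the scatter) and a number 1.64 log units lower from compound 2 to compound 3 (beyond the scatter); both are large, but each brings an oxan-3-yl in for a group without a ring oxygen. For the measured compounds named here, no measured step moves the oxygen within the ring, so there is no direct guide. Because compound 3 already gives 3.84 with the oxygen present, the expected step of a number 0.09 log units lower from compound 3 to compound 4 (within the scatter) is none beyond the scatter. Compound 4 is therefore estimated at 3.75, within 3.4 to 4.1.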

Compound 4, partition coefficient: 3.52
The estimate for compound 4 lay 0.23 log units above the measured number; measured number inside the range.
By their numbers in this assay, from the lowest: compound 4; then compound 3; then compounds 2 and 1 (each within the scatter of the next).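

Exchanging oxan-3-yl for oxan-4-yl on a carbonyl carbon leaves the atoms and the counts of donors and acceptors unchanged, yet in this assay the result is a number 0.32 log units lower from compound 3 to compound 4 (beyond the scatter) and so the number at this position depends on how the ring is joined, not only on whether it holds an oxygen. Against the groups without a ring oxygen, the steps of a number 1.96 log units lower from compound 2 to compound 4 (beyond the scatter) and a number 2.00 log units lower from compound 1 to compound 4 (beyond the scatter) leave compound 4 lowest of the four. Nothing measured here accounts for the difference between the two ether rings.

The compounds shown leave open whether a step of this kind persists with a ring amine such as piperidin-4-yl or a smaller ether ring such as oxolan-3-yl. They also leave open whether it would hold on any other core.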